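Shared core series: trifluoromethyl to chloro swap, second instance

The source may report more compounds than this note shows. Statements on the series, on what has been measured and on what is new or still open speak of the compounds shown alone.

Compound 1 `O=C(Nc1cccc(-n2cc(-c3ccncc3)c(-c3cc(O)cc(Cl)c3)n2)c1)Nc1ccc(Cl)c(C(F)(F)F)c1` in a functional assay on HOP-62 cells (Homo sapiens) for inhibition, read by sulforhodamine B assay, with a stated time of 48 h, tested at 10 uM (on this read-out higher numbers stand for a weaker effect at the one concentration tested and lower numbers for a stronger effect), gives 8.99%. Compound 2 `O=C(Nc1cccc(-n2cc(-c3ccncc3)c(-c3cc(O)cc(Cl)c3)n2)c1)Nc1ccc(Cl)c(Cl)c1` carries chloro in place of trifluoromethyl on an aromatic carbon, and in this assay compound 2 gives -44.2%; the step is a number 53.2 percentage points lower from compound 1 to compound 2 (beyond the scatter). Compound 3 `COc1cc(Cl)cc(-c2nn(-c3cccc(NC(=O)Nc4ccc(Cl)c(C(F)(F)F)c4)c3)cc2-c2ccncc2)c1` differs from compound 1 by methyl in place of hydrogen on an oxygen on an aromatic ring; in this assay compound 3 gives 13.5%, and the step of a number 4.5 percentage points higher from compound 1 to compound 3 (within the scatter) means compound 1 and compound 3 cannot be told apart on this read-out. Among the measured compounds shown here, no step between compound 2 and compound 3 is broken down here; their values simply stand far apart.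

Compound 4 `COc1cc(Cl)cc(-c2nn(-c3cccc(NC(=O)Nc4ccc(Cl)c(Cl)c4)c3)cc2-c2ccncc2)c1` is not yet measured. It differs from compound 3 by chloro in place of trifluoromethyl on an aromatic carbon, the same change as chloro in place of trifluoromethyl on an aromatic carbon, with the place described in the same words, so the surroundings of the swap match. The cores of the two pairs differ by methyl in place of hydrogen on an oxygen on an aromatic ring, which among the measured compounds moved the read-out only within the scatter.

With one earlier instance of the swap to go on, the expected step from compound 3 to compound 4 is a number 53.5 percentage points lower from compound 3 to compound 4 (beyond the scatter), set beside the earlier one, because the first instance gave a number 53.2 percentage points lower from compound 1 to compound 2 (beyond the scatter) on a core that has so far behaved alike. Resting on a single precedent, the range is kept wide. The estimate for compound 4 in this assay is -40%, expected to fall between -65% and -10%.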

Compound 4, a percentage reported as activity, at one concentration (the size of the read-out at that concentration, not a potency): 15.7%
The estimate for compound 4 lay 55.7 percentage points below the measured number; measured number outside the range, above it.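

In this assay, the swap of trifluoromethyl for chloro on the core of compound 3 gives a number 2.2 percentage points higher from compound 3 to compound 4 (within the scatter), and the large step seen on the core of compound 1 does not carry over to this core: the same change on two cores in this assay, a number 53.2 percentage points lower (beyond the scatter) from compound 1 to compound 2 and a number 2.2 percentage points higher (within the scatter) from compound 3 to compound 4, 55.4 percentage points apart, beyond the scatter of two such steps

Read along the other edge of the same four compounds, methyl on the oxygen gives a number 59.9 percentage points higher from compound 2 to compound 4 (beyond the scatter), so the two changes cannot be treated as independent in this series: the same change on two cores in this assay, a number 4.5 percentage points higher (within the scatter) from compound 1 to compound 3 and a number 59.9 percentage points higher (beyond the scatter) from compound 2 to compound 4, 55.4 percentage points apart, beyond the scatter of two such steps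

The difference rests on compound 2 alone, a single reading at one concentration, so these four compounds show that transfer of the swap failed here but give neither a general rule for other cores nor a reason for the dependence.

Still open, going by these compounds, is whether the large step needs the free hydroxyl specifically, which an amine or an ethoxy group in its place, each carried with both 4-chloro-3-(trifluoromethyl)phenyl and 3,4-dichlorophenyl, would help to separate. Also open, on these data alone, is whether a bromo or a nitrile in place of the chloro that enters behaves like chloro on the hydroxyl core or like trifluoromethyl.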